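The source may hold more compounds than are shown below. What is called first, only, known or untested is meant among the compounds shown, and "the series" means these compounds.

Measured compounds in a functional assay on PC-3 cells (Homo sapiens) for cytotoxicity, read by MTT assay, with a stated time of 48 h; on this read-out lower numbers stand for stronger inhibition and higher numbers for weaker inhibition:
compound 1 `COc1cc(C(=O)C2Sc3nnc(-c4cc(OC)c(OC)c(OC)c4)n3NC2c2ccco2)cc(OC)c1OC` gives 52200 nM
compound 2 `COc1cc(-c2nnc3n2NC(c2ccco2)C(C(=O)c2ccc(Br)cc2)S3)cc(OC)c1OC` gives 36400 nM
compound 3 `COc1cc(-c2nnc3n2NC(c2ccco2)C(C(=O)C2CC2)S3)cc(OC)c1OC` gives 95200 nM

Compound 3 carries the highest number of the three. Its distance from compound 1 is within the scatter, a 1.8-fold higher number from compound 1 to compound 3 (0.26 log units; within the scatter), whereas its distance from compound 2 lies beyond it, a 2.6-fold higher number from compound 2 to compound 3 (0.42 log units; beyond the scatter). The step from compound 1 to compound 2, a 1.4-fold lower number from compound 1 to compound 2 (0.16 log units; within the scatter), stays within the scatter.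

Compound 4 `COc1cc(-c2nnc3n2NC(c2ccco2)C(C(=O)c2cccc(Br)c2)S3)cc(OC)c1OC` has not been measured. It differs from compound 3 in one place: 3-bromophenyl in place of cyclopropyl on a carbonyl carbon. Going by the values given here, the step that bears most directly on this change is the one between compound 2 and compound 3, where 4-bromophenyl gave way to cyclopropyl and the number rose beyond the scatter. Compound 4 reverses that kind of change, with the bromine carried on a 3-bromophenyl instead. A modest fall in the number is therefore expected, roughly mirroring the measured step. The expected step from compound 3 to compound 4 in this assay is a 2.4-fold lower number from compound 3 to compound 4 (0.38 log units; beyond the scatter). Compound 4 is estimated at 40000 nM, with a range of 20000 nM to 85000 nM.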

Compound 4, half-maximal inhibitory concentration: 63900 nM
Beside the measured number, compound 4's estimate is 1.6-fold (0.20 log units) below it, within the range that was stated.
By their numbers in this assay, from the lowest: compounds 2, 1, 4 and 3 (each within the scatter of the next, the first and the last beyond it).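

On the carbonyl carbon, 3-bromophenyl in place of cyclopropyl in this assay gives a 1.5-fold lower number from compound 3 to compound 4 (0.17 log units; within the scatter), so this change does not reproduce the separation seen with 4-bromophenyl, a 2.6-fold higher number from compound 2 to compound 3 (0.42 log units; beyond the scatter). Exchanging 4-bromophenyl for 3-bromophenyl gives a 1.8-fold higher number from compound 2 to compound 4 (0.24 log units; within the scatter), and exchanging 3,4,5-trimethoxyphenyl for 3-bromophenyl gives a 1.2-fold higher number from compound 1 to compound 4 (0.09 log units; within the scatter), so compound 4 cannot be told apart from compounds 1, 2 or 3, and a bromophenyl on the carbonyl carbon does not by itself mark out a separate level. No measured evidence accounts for these results.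

Going by these compounds alone, the one separation beyond the scatter still rests on the single pair of compound 2 and compound 3. On these data alone, whether an aminophenyl, a carboxyphenyl or a longer chain such as n-butyl on the carbonyl carbon would move the number beyond the scatter remains open.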